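From bromo to phenyl on compound 1

The source may hold more compounds than are shown below. What is called first, only, known or untested is meant among the compounds shown, and "the series" means these compounds.

- compound 1 `Cn1c([N+](=O)[O-])cnc1/C=C/c1ccccc1Br` gives 72400 nM as its value
- compound 2 `Cn1c([N+](=O)[O-])cnc1/C=C/c1ccc(Br)cc1` gives 72400 nM as its value
- compound 3 `COc1cccc(/C=C/c2ncc([N+](=O)[O-])n2C)c1` gives > 100000 nM (a limit of the assay, not a number)

Compound 1 gives 72400 nM in an ADME assay on HeLa cells (Homo sapiens) for cytotoxicity, read by resazurin assay, with a stated time of 2 days (a lower number here means a stronger inhibitor, a higher number a weaker inhibitor), and stands level with compound 2 at 72400 nM within the scatter. The entry for compound 3 at > 100000 nM is a limit of the assay.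

Compound 4 `Cn1c([N+](=O)[O-])cnc1/C=C/c1ccccc1-c1ccccc1` carries phenyl in place of bromo on an aromatic carbon of compound 1 (phenyl in place of bromo on an aromatic carbon). Going by the values given here, no measured step covers this exchange. The expectation rests on compound 1 at 72400 nM and compound 2 at 72400 nM alone. The estimated 1.2-fold lower number from compound 1 to compound 4 (0.08 log units; within the scatter) in this assay is expected to stay within the scatter, with no firm direction. Compound 4 is estimated at 60000 nM (expected range 20000 nM to 100000 nM).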

Compound 4, half-maximal inhibitory concentration: > 100000 nM
Compound 4: a limit, no number (the forecaster's own chance of this, stated with the estimate: 35%); middle value at least 1.6-fold (0.22 log units) from the limit.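

In this assay compound 4 gives > 100000 nM, which is a limit of the assay and not a number. With phenyl in place of bromo on an aromatic carbon, the series shows an at least 1.3-fold higher number from compound 1 to compound 4 (0.14 log units; that floor lies within the scatter), so the larger aromatic group at this position brings no visible fall in the number, and the true size of the step stays unread. What this exchange can show is capped by the top of the assay range: the limit of > 100000 nM in this assay, at which 2 of the 4 values shown sit.

Still open, on these data alone, is how far past the limit compound 4 lies, so a real rise cannot be told from a small shift. Also open, as far as these compounds go, is how this position reads with a methyl or chloro in place of bromo, or with an amine or carboxylic acid carried on the added phenyl.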